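One ring group exchanged for 3-oxopiperazin-1-yl

The compounds below may be only part of what the source reports. "The series", "measured", "known", "first", "only" and "open" are said of these compounds alone.

- compound 1 `COC(=O)C1=C(C)NC(c2nccs2)=NC1(C)c1ccc(F)cc1`: 22 ug/mL
- compound 2 `COC(=O)C1=C(CN2CCNCC2)NC(c2nccs2)=NC1(C)c1ccc(F)cc1`: 250 ug/mL
- compound 3 `COC(=O)C1=C(CN2CC3CC2CO3)NC(c2nccs2)=NC1(C)c1ccc(F)cc1`: 564 ug/mL

These values come from a physicochemical assay for solubility, read by HPLC, in phosphate buffer, at pH 6.5 (a lower number here means a less soluble compound, a higher number a more soluble compound), where compound 3 stands highest of the three. Compound 4 `COC(=O)C1=C(CN2CCNC(=O)C2)NC(c2nccs2)=NC1(C)c1ccc(F)cc1` differs from it in one group: a group of 7 heavy atoms (4 carbon, 2 nitrogen, 1 oxygen; one six-membered non-aromatic ring with 2 hetero atoms) in place of a group of 7 heavy atoms (5 carbon, 1 nitrogen, 1 oxygen; 2 five-membered non-aromatic rings with 1 hetero atom each), on a saturated chain carbon bound to a double-bonded ring carbon. Two measured steps at this same place were large: an 11-fold higher number from compound 1 to compound 2 (1.06 log units; beyond the scatter), and a 26-fold higher number from compound 1 to compound 3 (1.41 log units; beyond the scatter). Both started from hydrogen, so they say little here. Compound 2 and compound 4 both carry a six-membered non-aromatic ring with 2 hetero atoms, which makes the modest 2.3-fold higher number from compound 2 to compound 3 (0.35 log units; beyond the scatter) the closest guide. A modest fall is therefore expected in this assay, an estimated 2.2-fold lower number from compound 3 to compound 4 (0.34 log units; beyond the scatter). The estimate for compound 4 is 260 ug/mL, with an expected range of 90 ug/mL to 650 ug/mL.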

Compound 4, solubility: 34 ug/mL
Estimate against measurement, compound 4: 7.6-fold (0.88 log units) above; the whole stated range lies above it.
By their numbers in this assay, from the lowest: compounds 1 and 4 (each within the scatter of the next); then compound 2; then compound 3.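

In this assay, having a ring at this place is not enough to secure a large step up from hydrogen: 3-oxopiperazin-1-yl in place of piperazin-1-yl gives a 7.4-fold lower number from compound 2 to compound 4 (0.87 log units; beyond the scatter), and in place of the two-ring group it gives a 17-fold lower number from compound 3 to compound 4 (1.22 log units; beyond the scatter). Against hydrogen, the result is a 1.5-fold higher number from compound 1 to compound 4 (0.19 log units; within the scatter), so the two cannot be told apart here.

Nothing available here explains this difference between the groups. On these data alone, it remains open whether morpholin-4-yl or an open-chain amine such as dimethylamino would stand nearer compound 3 or compound 4.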